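A few compounds are considered here, and "the series" means these few. Any claim that something is new, unique, unknown or untested is made for them only; others in the source may bear on it.

Working notes on the series, read in a functional assay on HL-60 cells (Homo sapiens) for cytotoxicity, read by luminescence and CellTiter-Glo, with a stated time of 3 days; on this read-out lower numbers stand for stronger inhibition and higher numbers for weaker inhibition. Here compound 1 `O=C(Nc1ccc(Cl)c(Cl)c1)c1cc(F)ccc1O` gives 660 nM. Compound 3 `O=C(Nc1ccc(C(F)(F)F)cc1)c1ccc2cccnc2c1O` gives 680 nM, which lies within the scatter of the value for compound 1. Compound 2 `N#Cc1ccc(NC(=O)c2c(O)cccc2F)cc1` reads > 10000 nM, and this is a limit of the assay, not a number.

Compound 4 `Cc1cccc(O)c1C(=O)Nc1ccc(C#N)cc1` is the next to be read in this assay. It differs from compound 2 as follows: methyl in place of fluoro on an aromatic carbon. That is methyl in place of fluoro on an aromatic carbon, ortho to a large group and meta to a hydroxy group.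

Among the measured compounds shown here, no measured pair isolates a change of this kind, so the data give no direct size for it. The expected result is a step that the limit leaves unreadable from compound 2 to compound 4, a step not expected to go beyond the scatter in either direction. This expectation rests on compound 2, whose reading of > 10000 nM is a limit. Another reading at the limit is also expected to be likely. For compound 4 the estimate is 12000 nM, with an expected range of 3000 nM to 40000 nM.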

Compound 4, half-maximal inhibitory concentration: 6860 nM
The estimate for compound 4 lay 1.7-fold (0.24 log units) above the measured number, within the range that was stated.
By their numbers in this assay, from the lowest: compounds 1 and 3 (each within the scatter of the next); then compound 4. At a limit, above all of these: compound 2.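

In this assay, methyl in place of fluoro on an aromatic carbon, ortho to a large group and meta to a hydroxy group, gives an at least 1.4-fold lower number from compound 2 to compound 4 (0.16 log units; that floor lies within the scatter). Among the compounds shown here, this is the first measured change at this position, and with methyl compound 4 gives a number where fluoro in compound 2 gives only a limit. Whether the step truly goes beyond the scatter cannot be read because the value for compound 2 is a limit, not a number: the limit of > 10000 nM in this assay, at which 1 of the 4 values shown sits.

Going by these compounds, whether an amine or a methoxy group on this same carbon would read lower or higher than methyl remains open. Also open, on these data alone, is whether methyl in place of fluoro would give a similar step on the core of compound 1, where the fluoro stands at a different place.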